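From 3-fluorophenyl to 4-fluorophenyl: a step between limits

The source may report more compounds than this note shows. Statements on the series, on what has been measured and on what is new or still open speak of the compounds shown alone.

In an ADME assay on THP-1 cells (Homo sapiens) for cytotoxicity, read by flow cytometry and propidium iodide staining, with a stated time of 72 h (a higher number here means a weaker inhibitor, a lower number a stronger inhibitor), compound 1 `COc1ccc(-c2oc3ccc(NC(C)=O)cc3c(=O)c2OC)cc1` gives > 50000 nM, which is a limit. Compound 2 `COc1c(-c2ccccc2F)oc2ccc(NC(C)=O)cc2c1=O` gives > 125000 nM, also a limit. Compound 3 `COc1c(-c2cccc(F)c2)oc2ccc(NC(C)=O)cc2c1=O` gives > 125000 nM, again a limit and not a number. Compound 3 therefore stands at the limit of > 125000 nM in this assay, at which 2 of the 3 values shown sit.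

Compound 4 `COc1c(-c2ccc(F)cc2)oc2ccc(NC(C)=O)cc2c1=O` carries 4-fluorophenyl in place of 3-fluorophenyl on an aromatic carbon. The change sits next to the ring oxygen and ortho to a methoxy group.

Among the compounds with values here, three measured steps bear on it: a step that the two limits leave unreadable from compound 2 to compound 3, a step that the two limits leave unreadable from compound 1 to compound 2 and a step that the two limits leave unreadable from compound 1 to compound 3. None of them has a readable size, so none supports a direction. No step beyond the scatter is expected in this assay, and another limit is the likeliest report. The estimated step is a number no higher from compound 3 to compound 4 (the limit leaves the size open). For compound 4 the expected value is 125000 nM, with an estimated range from 60000 nM to 250000 nM.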

Compound 4, half-maximal inhibitory concentration: > 125000 nM
Compound 4 gave a limit, no number (the forecaster's own chance of this, stated with the estimate: 85%); the middle value lies on the limit itself.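

In this assay compound 4 gives > 125000 nM, a limit and not a number. Its steps from compound 1, compound 2 and compound 3 cannot be read, as all four values are limits. The compounds shown leave open whether 2-fluorophenyl, 3-fluorophenyl and 4-fluorophenyl differ at all in this assay.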